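Adding a Methyl Group to Compound 2

The source may hold more compounds than are shown below. What is called first, only, known or untested is meant among the compounds shown, and "the series" means these compounds.

Among the measured compounds shown here, in a functional assay on MDA-N cells (Homo sapiens) for antiproliferative activity (a higher number here means a weaker inhibitor of growth, a lower number a stronger inhibitor of growth), compound 2 `Oc1cc(-c2ccc3ccccc3c2)nc2ncccc12` gives 1660 nM, the highest of the three numbers measured so far. Compound 3 `Cc1ccnc2nc(-c3ccc4ccccc4c3)cc(O)c12` gives 204 nM, and compound 1 `Cc1ccnc2nc(-c3cccc(Cl)c3)cc(O)c12` gives the lowest number, 11.8 nM.

Compound 4 `Cc1ccc2c(O)cc(-c3ccc4ccccc4c3)nc2n1` differs from compound 2 in one place: methyl in place of hydrogen on an aromatic carbon. This puts methyl in place of hydrogen on an aromatic carbon, next to the ring nitrogen.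

For the measured compounds named here, the one measured step that bears on this change is an 8.1-fold lower number from compound 2 to compound 3 (0.91 log units; beyond the scatter). It also swaps hydrogen for methyl, but on a different carbon, so it offers only a loose guide from a single example. Going by the values given here, no measurement yet shows what methyl does at the new place. The expectation is therefore a step in the same direction but smaller, and a result within the scatter would be no surprise. The estimated step is a 2.4-fold lower number from compound 2 to compound 4 (0.38 log units; beyond the scatter). The expected value for compound 4 is 700 nM, within an estimated range of 180 nM to 2500 nM.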

Compound 4, concentration for 50% growth inhibition: 1950 nM
Compound 4: middle estimate off by 2.8-fold (0.44 log units), on the low side; the range from low to high includes it.
By their numbers in this assay, from the lowest: compound 1; then compound 3; then compounds 2 and 4 (each within the scatter of the next).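

In this assay, methyl in place of hydrogen next to the ring nitrogen gives a 1.2-fold higher number from compound 2 to compound 4 (0.07 log units; within the scatter), so at this place the change does not move the number beyond the scatter. The same swap on a different carbon gave an 8.1-fold lower number from compound 2 to compound 3 (0.91 log units; beyond the scatter), which lies beyond the scatter, so across these two examples the effect of a methyl depends on where it sits. No measurement shown here accounts for the difference between the two places.

The compounds shown leave open what an amine, a methoxy group or a longer chain such as ethyl would do at this same place. Also open, as far as these compounds go, is whether methyl at this place would behave the same way of compound 1, which gives 11.8 nM.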